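The source may hold more compounds than are shown below. What is called first, only, known or untested is meant among the compounds shown, and "the series" means these compounds.

Compound 3, `CN(C)CCn1cc[n+](C)c1/C=N/O`, is one of a small set of oxime-bearing compounds measured in a physicochemical assay for lipophilicity; a lower number here means a more polar compound, a higher number a more lipophilic compound. Of the two numbers obtained in this assay, compound 3 gives the lower one, at -3.06. Its nearest neighbour is compound 1, `C[n+]1ccn(CCCCC#N)c1/C=N/O`, which in this assay gives -2.8; the two numbers are within the scatter of each other, so no order between them is claimed. Compound 2, `C[n+]1ccn(CC[N+](=O)[O-])c1/C=N/O`, belongs to the same series, and in this assay compound 2 gives no result reported.

Compound 4, `CN(CCn1cc[n+](C)c1/C=N/O)S(C)(=O)=O`, differs from compound 3 by a single change: methylsulfonyl in place of methyl on an amine nitrogen. Within the data shown here, only one measured step is available for comparison, and it concerns a different change, the replacement of a 2-cyanoethyl group by a dimethylamino group two bonds from an aromatic nitrogen, which gave a number 0.26 log units lower from compound 1 to compound 3 (within the scatter). Among the measured compounds shown here, that step is within the scatter and does not mirror the present exchange, so it bears on it only loosely; the data hold no step in which a methyl on an amine nitrogen is replaced by methylsulfonyl.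

For compound 4 the expectation is therefore tentative: the estimated step is a number 0.66 log units higher from compound 3 to compound 4 (beyond the scatter), a modest rise in this assay. Compound 4 is accordingly expected to give about -2.4 in this assay, with a range from -3.3 to -1.5.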

Compound 4, distribution coefficient: -3.31
Compound 4: the middle estimate sits 0.91 log units above what was measured; measured number below the stated range.
By their numbers in this assay, from the lowest: compounds 4, 3 and 1 (each within the scatter of the next, the first and the last beyond it).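

In this assay, among these compounds, the exchange at this position gives a number 0.25 log units lower from compound 3 to compound 4 (within the scatter) and is the only measured step at an amine nitrogen whose other neighbours are two saturated chain carbons. It shows that methylsulfonyl, with 4 heavy atoms and 2 hydrogen-bond acceptors, can stand in place of methyl, with 1 heavy atom and 0 hydrogen-bond acceptors, while compound 4 stays within the scatter of compound 3 in this read-out. No independent evidence is available to account for this outcome.

Going by these compounds, whether an acetyl group or an ethyl group on the same amine nitrogen would also stay within the scatter of compound 3 in this assay remains open. The compounds shown also leave open how methylsulfonyl would read on a longer chain, and how a carboxylic acid in place of the whole amine would compare with compound 3 and compound 4.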